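Cutting the Side Chain Down to Acetyl

This account rests on a few compounds, and the source may have more. Where it says the series, first, only, none or still open, it means among the compounds named here.

For the measured compounds named here, compound 2 `Cc1c(OCCCCOc2ccc(C(=O)CC(C)(C)C)c(O)c2C)cccc1C(=O)O` stands at the highest of the two numbers so far in an assay on HEK293 cells for positive allosteric modulation of metabotropic glutamate receptor 2 (Rattus norvegicus), read by thallium flux, with a stated time of 2.5 min (on this read-out lower numbers stand for an effect already at smaller amounts and higher numbers for an effect only at larger amounts of compound), giving 136 nM; its only neighbour, compound 1 `CCC(=O)c1ccc(OCCCCOc2cccc(C(=O)O)c2C)c(C)c1O`, gives 62 nM. Compound 3 `CC(=O)c1ccc(OCCCCOc2cccc(C(=O)O)c2C)c(C)c1O` carries one further change at the same place: hydrogen in place of tert-butyl on a saturated chain carbon bound to a carbonyl carbon. Going by the values given here, the single measured step that bears on this position is a 2.2-fold higher number from compound 1 to compound 2 (0.34 log units; beyond the scatter), a modest rise when the larger group came in. Going the other way and further, compound 3 is expected to move back, an estimated step of a 1.9-fold lower number from compound 2 to compound 3 (0.29 log units; within the scatter). Compound 3 is therefore estimated at 70 nM, with a range of 30 nM to 160 nM.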

Compound 3, half-maximal effective concentration: 200 nM
Compound 3: the middle estimate sits 2.9-fold (0.46 log units) below what was measured; the whole stated range lies below it.
By their numbers in this assay, from the lowest: compound 1; then compounds 2 and 3 (each within the scatter of the next).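

Replacing tert-butyl with hydrogen leaves compounds 2 and 3 level in this assay, with a 1.5-fold higher number from compound 2 to compound 3 (0.17 log units; within the scatter), so the smallest group on this carbon does not bring the number down. Hydrogen in place of methyl instead gives a 3.2-fold higher number from compound 1 to compound 3 (0.51 log units; beyond the scatter), which leaves compound 1 with the lowest number and shows that the three compounds do not line up by the size of the group. Nothing at hand explains this pattern. Still open, from the compounds shown here alone, is whether ethyl or isopropyl on this carbon would match compound 1 or improve on it.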